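The source may report more compounds than this note shows. Statements on the series, on what has been measured and on what is new or still open speak of the compounds shown alone.

Compound 1 `Cc1cc(Br)c(Oc2nc(Nc3ccc(C#N)cc3)nc3ccccc23)c(Br)c1`: 25000 nM
Compound 2 `COc1cc(C#N)cc(Cl)c1Oc1nc(Nc2ccc(C#N)cc2)nc2ccccc12`: 220000 nM
Compound 3 `CCCOc1cc(C#N)cc(OC)c1Oc1nc(Nc2ccc(C#N)cc2)nc2ccccc12`: 5200 nM

In an ADME assay on MT4 cells (Homo sapiens) for cytotoxicity, read by MTT assay, with a stated time of 4 days (on this read-out higher numbers stand for lower toxicity in this test and lower numbers for higher toxicity in this test), compound 1 gives 25000 nM and stands second highest of the three numbers, between compound 3 with 5200 nM and compound 2 with 220000 nM. Among the measured compounds shown here, the only single-place step among the measured compounds is a 42-fold lower number from compound 2 to compound 3 (1.63 log units; beyond the scatter). Compound 4 `N#Cc1ccc(Nc2nc(Oc3ccccc3)c3ccccc3n2)cc1` has not yet been measured in this assay. It differs from compound 1 by phenyl in place of 2,6-dibromo-4-methylphenyl on an oxygen on an aromatic ring. For the measured compounds named here, the step from compound 2 to compound 3 changes a different position of the aryl ether ring and swaps one substituent for another rather than removing three, so it does not bear directly on this change; it shows only that substitution on that ring can move this assay by a large amount. Going by the values given here, with no closely related step available, the direction for compound 4 is uncertain, and a modest move toward a higher number is expected, a 2.4-fold higher number from compound 1 to compound 4 (0.38 log units; beyond the scatter). Compound 4 is therefore estimated at 60000 nM, within a range of 15000 nM to 250000 nM.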

Compound 4, half-maximal cytotoxic concentration: 370000 nM
For compound 4 the middle estimate is 6.2-fold (0.79 log units) below the measured one, outside the stated range (above it).
By their numbers in this assay, from the lowest: compound 3; then compound 1; then compounds 2 and 4 (each within the scatter of the next).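

In this assay the step of a 15-fold higher number from compound 1 to compound 4 (1.17 log units; beyond the scatter) shows that the group on this oxygen can move the number a long way even when nothing takes the place of the two bromines and the methyl, whereas the earlier step of a 42-fold lower number from compound 2 to compound 3 (1.63 log units; beyond the scatter) showed a large move only for one substituent exchanged for another. Here the bare phenyl goes with the higher number, which stands for lower toxicity in this test. No measurement shown gives a reason for this shift.

The step changes the two bromines and the methyl together, so the compounds shown leave open how much of it belongs to each of them. They also leave open how this assay would read with a single bromo on the phenyl, or with an amine or a carboxylic acid there.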